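Chlorine on the furan and topoisomerase inhibition

The compounds below may be only part of what the source reports. "The series", "measured", "known", "first", "only" and "open" are said of these compounds alone.

Of the compounds shown here, three built on one shared core have been measured in an assay on isolated protein for inhibition of DNA topoisomerase 1 (Homo sapiens), tested at 100 uM; on this read-out higher numbers stand for a stronger effect at the one concentration tested and lower numbers for a weaker effect. Compound 1 `Clc1ccc(-c2cc(-c3ccc(Cl)o3)cc(-c3ccsc3)n2)cc1` gives 29.8% in this assay. Compound 2 `Clc1cccc(-c2cc(-c3ccc(Cl)o3)cc(-c3cccs3)n2)c1` gives 42%. Compound 3 `Clc1ccc(-c2cc(-c3ccco3)cc(-c3cccs3)n2)cc1` gives 2.7%, the lowest of the three numbers; its distance to compound 1, the nearest, and to compound 2, the furthest, both lie beyond the usual scatter. Compound 4 `Clc1ccc(-c2cc(-c3ccc(Cl)o3)cc(-c3cccs3)n2)cc1` is not yet measured. It differs from compound 3 in one place: chloro in place of hydrogen on an aromatic carbon. Compound 1 and compound 2 both carry 5-chlorofuran-2-yl and both sit well above compound 3, the only one with furan-2-yl, which is the sole pattern in these three numbers. On that basis the change is expected to raise the reading, with an estimated step of a number 30.3 percentage points higher from compound 3 to compound 4 (beyond the scatter), beyond the scatter. Compound 4 is therefore expected to give about 33%, most likely between 10% and 55%, because compound 1 gives 29.8% and compound 2 gives 42% with the same group in place.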

Compound 4, a percentage reported as inhibition, at one concentration (the size of the read-out at that concentration, not a potency): 38.9%
Estimate against measurement, compound 4: 5.9 percentage points below; measured number inside the range.
By their numbers in this assay, from the lowest: compound 3; then compounds 1, 4 and 2 (each within the scatter of the next, the first and the last beyond it).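

In this assay the chloro group can now be read on its own, with the rest of the shared core unchanged: chloro in place of hydrogen, furan-2-yl to 5-chlorofuran-2-yl, gives a number 36.2 percentage points higher from compound 3 to compound 4 (beyond the scatter) and so accounts for a large step in a single change. With 5-chlorofuran-2-yl in place, 4-chlorophenyl in place of 3-chlorophenyl gives a number 3.1 percentage points lower from compound 2 to compound 4 (within the scatter) and thiophen-2-yl in place of thiophen-3-yl gives a number 9.1 percentage points higher from compound 1 to compound 4 (within the scatter), and both steps lie within the scatter, so neither swap separates these compounds. Nothing at hand explains the size of the chloro step.

Going by these compounds, whether a bromine, a methyl or an amine on the same carbon would read like chloro stays open. So does whether the chloro step would be the same size with 3-chlorophenyl or thiophen-3-yl on the core.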